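This account rests on a few compounds, and the source may have more. Where it says the series, first, only, none or still open, it means among the compounds named here.

Working notes on the series.

Compound 1 `CO/N=c1\[nH]cnc2c1[n+](C/C=C(\C)CC/C=C(/C)CCC=C(C)C)cn2C` and compound 2 `CC(C)=CCC/C(C)=C\CC/C(C)=C/C[n+]1cn(C)c2nc[nH]/c(=N\OCc3ccccc3)c21` share one core; compound 3 `CO/N=c1\[nH]cnc2c1[n+](C/C=C(\C)CC/C=C(\C)CC/C=C(\C)CCC=C(C)C)cn2C(c1ccccc1)c1ccccc1` and compound 4 `CC(C)=CCC/C(C)=C/CC/C(C)=C/CC/C(C)=C/C[n+]1cn(C(c2ccccc2)c2ccccc2)c2nc[nH]/c(=N\OCc3ccccc3)c21` share another, and the difference between the two cores is not broken down here. In a functional assay on CEM/s cells (Homo sapiens) for cytotoxicity (a higher number here means a weaker inhibitor, a lower number a stronger inhibitor), compound 1 gives 1230 nM. Compound 2 gives 10000 nM in this assay. Compound 3 gives 3540 nM in this assay, which puts it second highest of the three numbers, beyond the scatter from both compound 1 and compound 2.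

The change from compound 1 to compound 2 is phenyl in place of hydrogen on a saturated chain carbon bound to an oxygen, and it moved the number by an 8.1-fold higher number from compound 1 to compound 2 (0.91 log units; beyond the scatter). The change from compound 3 to compound 4 is phenyl in place of hydrogen on a saturated chain carbon bound to an oxygen. Its place reads the same word for word as in the first pair, so it is the same change, seen twice among the four compounds.

Compound 4 is not yet measured in this assay. For the measured compounds named here, because the one measured instance of this change gave an 8.1-fold higher number from compound 1 to compound 2 (0.91 log units; beyond the scatter), a step of similar size and direction is expected, a 6.2-fold higher number from compound 3 to compound 4 (0.79 log units; beyond the scatter). This rests on a single pair on a different core, so the expectation is loose. On that basis compound 4 is estimated at 22000 nM in this assay, with a range expected from 7000 nM to 60000 nM; a reading at the upper edge of the assay would not be surprising.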

Compound 4, half-maximal inhibitory concentration: 9110 nM
The estimate for compound 4 lay 2.4-fold (0.38 log units) above the measured number; the measured number falls inside the stated range.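

In this assay, replacing methoxy with benzyloxy gave a 2.6-fold higher number from compound 3 to compound 4 (0.41 log units; beyond the scatter), so the change moved the number in the same direction on the second core as on the first. The direction carried over, but the size of the step did not: the same change on two cores in this assay, an 8.1-fold higher number (0.91 log units; beyond the scatter) from compound 1 to compound 2 and a 2.6-fold higher number (0.41 log units; beyond the scatter) from compound 3 to compound 4, 3.2-fold (0.50 log units) apart, beyond the scatter of two such steps These two pairs show that the change can be taken from one core to the other with the same sign, but they give no basis for transferring a step size, and they do not show which part of the difference between the cores goes with the smaller step on the core of compound 3.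

The compounds shown leave open how the number responds to other groups on the same oxygen, such as ethoxy, a longer chain such as phenethyloxy, or a benzyloxy whose phenyl ring carries a fluorine, an amine or a carboxylic acid. They also leave open whether the same direction would appear on a third core, and whether the step size would then lie closer to that of the first pair or the second.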